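This account rests on a few compounds, and the source may have more. Where it says the series, first, only, none or still open, it means among the compounds named here.

In a functional assay on LNCaP cells (Homo sapiens) for antiproliferative activity, read by propidium iodide staining, with a stated time of 96 h (a lower number here means a stronger inhibitor, a higher number a weaker inhibitor), three related compounds have been measured so far. Compound 1 (`CC(O)(CSc1cccc(S(F)(F)(F)(F)F)c1)C(=O)Nc1ccc(C#N)c(C(F)(F)F)c1`) gives 14500 nM, and compound 2 (`CC(O)(COc1ccc(S(F)(F)(F)(F)F)cc1)C(=O)Nc1cc(C(F)(F)F)cc(C(F)(F)F)c1`) gives 1900 nM. Compound 3 (`CC(O)(CS(=O)(=O)c1cccc(S(F)(F)(F)(F)F)c1)C(=O)Nc1ccc(S(F)(F)(F)(F)F)cc1`) gives 31300 nM, the highest number of the three and so the weakest inhibitor, with its gaps to both others beyond the scatter.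

Compound 4 (`CC(O)(CS(=O)(=O)c1cccc(OC(F)(F)F)c1)C(=O)Nc1ccc(S(F)(F)(F)(F)F)cc1`) has not yet been measured. It departs from compound 3 at a single place: a group of 5 heavy atoms (1 carbon, 1 oxygen, 3 fluorine; no ring) in place of a group of 6 heavy atoms (5 fluorine, 1 sulfur; no ring), on an aromatic carbon. The exchange sits on an aromatic carbon of a six-membered aromatic ring of carbon only, meta to a large group, and trifluoromethoxy is the group that enters.

Among the measured compounds shown here, no two measured compounds differ in one place only, so the data give no direct measure of such an exchange. In this assay, no step beyond the scatter is expected, with a slight lean toward a lower number. The expectation is anchored on compound 3 at 31300 nM, whose structure otherwise stays unchanged. The estimated change is a 1.6-fold lower number from compound 3 to compound 4 (0.19 log units; within the scatter). Compound 4 is estimated at 20000 nM, with an expected range from 7000 nM to 50000 nM.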

Compound 4, half-maximal inhibitory concentration: 21700 nM
Compound 4: the middle estimate sits 1.1-fold (0.04 log units) below what was measured, and the stated range covers the measured number.
By their numbers in this assay, from the lowest: compound 2; then compounds 1, 4 and 3 (each within the scatter of the next, the first and the last beyond it).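

In this assay, among the compounds shown here, this pair gives the first reading of a change at a single place: trifluoromethoxy takes the place of the group of 6 heavy atoms (5 fluorine, 1 sulfur) on an aromatic carbon, meta to a large group, and the exchange gives a 1.4-fold lower number from compound 3 to compound 4 (0.16 log units; within the scatter) with the rest of the structure unchanged. For the compounds shown here, at this position, therefore, the two groups cannot be told apart in this read-out, something the earlier compounds, none differing in one place only, could not show. Nothing available accounts for this result.

As far as these compounds go, whether an amine, a carboxylic acid or a longer chain at this position would also leave the number within the scatter remains open. From the compounds shown here alone, it is equally open whether the same exchange would give a similar step on the core of compound 1.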